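From Carboxy to Carbamoyl on a Shared Core

The compounds below may be only part of what the source reports. "The series", "measured", "known", "first", "only" and "open" are said of these compounds alone.

For the measured compounds named here, in a functional assay on Fem-X cells (Homo sapiens) for cytotoxicity (on this read-out lower numbers stand for stronger inhibition and higher numbers for weaker inhibition), compound 2 (`O=C(O)C1CCC2(CC1)OOC1(CCCCC1)OO2`) gives 155000 nM, the highest of the two numbers measured so far. Going by the values given here, the only other measured compound, compound 1 (`COC(=O)C1CCC2(CC1)OOC1(CCCCC1)OO2`), gives 72400 nM. Compound 3 (`NC(=O)C1CCC2(CC1)OOC1(CCCCC1)OO2`) differs from compound 2 by amino in place of hydroxy on a carbonyl carbon, or carboxy to carbamoyl (amino in place of hydroxy on a carbonyl carbon). Among the compounds with values here, only one measured step bears on this change, and only indirectly: a 2.1-fold higher number from compound 1 to compound 2 (0.33 log units; beyond the scatter), a modest step that ends at the carboxy group. Within the data shown here, no compound with a carbamoyl group has yet been measured, so this step offers only a rough guide to size. A small step, none beyond the scatter, is therefore expected in this assay: a 1.6-fold lower number from compound 2 to compound 3 (0.19 log units; within the scatter). Compound 3 is estimated at 100000 nM, with an expected range from 50000 nM to 200000 nM.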

Compound 3, half-maximal inhibitory concentration: 120000 nM
Estimate against measurement, compound 3: 1.2-fold (0.08 log units) below, and the stated range covers the measured number.
By their numbers in this assay, from the lowest: compounds 1, 3 and 2 (each within the scatter of the next, the first and the last beyond it).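

At this position, on a carbonyl carbon, amino in place of hydroxy gives a 1.3-fold lower number from compound 2 to compound 3 (0.11 log units; within the scatter) in this assay, so this change stays within the scatter. Amino in place of methoxy gives a 1.7-fold higher number from compound 1 to compound 3 (0.22 log units; within the scatter) as well, again within the scatter. Compound 3 therefore cannot be told apart from either compound 1 or compound 2, although those two differ from each other beyond the scatter, and nothing available here accounts for these numbers.

The compounds shown leave open what substituted amides such as the methylamide or dimethylamide, or a longer chain on the ester oxygen, would give at this position. From the compounds shown here alone, it also remains open whether a nitrile or an amine in place of the whole carbonyl group would move the number beyond the scatter.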